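The source may hold more compounds than are shown below. What is called first, only, known or untested is meant among the compounds shown, and "the series" means these compounds.

Of the compounds shown here, three built on a shared core have been measured in a functional assay on DU-145 cells (Homo sapiens) for cytotoxicity, read by trypan blue exclusion, with a stated time of 96 h; on this read-out higher numbers stand for weaker inhibition and lower numbers for stronger inhibition. In this assay, compound 1 `COc1ccc(/C=C/S(=O)(=O)Cc2ccc(OC)c(N)c2)c(OC)c1` gives 500 nM, compound 2 `COc1ccc(CS(=O)(=O)/C=C/c2cc(OC)c(OC)cc2OC)cc1N` gives 250 nM and compound 3 `COC(=O)CNc1cc(CS(=O)(=O)/C=C/c2c(OC)cc(OC)cc2OC)ccc1OC` gives 100 nM. Compound 3 therefore has the lowest number of the three, and its gaps to both others lie beyond the usual scatter, which makes it the strongest inhibitor so far.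

Compound 4 `COC(=O)C(Nc1cc(CS(=O)(=O)/C=C/c2c(OC)cc(OC)cc2OC)ccc1OC)c1ccccc1` differs from compound 3 in one place, a saturated chain carbon bound to a carbonyl carbon and a nitrogen on an aromatic ring. The change there is phenyl in place of hydrogen on a saturated chain carbon bound to a carbonyl carbon and a nitrogen on an aromatic ring.

Among the measured compounds shown here, only one measured step links two close relatives: a 2.0-fold lower number from compound 1 to compound 2 (0.30 log units; within the scatter). It stays within the scatter, and it is a different change, methoxy in place of hydrogen on an aromatic carbon. For the measured compounds named here, it offers only weak guidance, and no measured compound carries a phenyl on this chain carbon.

No step beyond the scatter is therefore expected, with only a slight lean towards a higher number, since compound 3 at 100 nM already sits lowest. The expected step is a 1.5-fold higher number from compound 3 to compound 4 (0.18 log units; within the scatter). For compound 4 the estimate is 150 nM, with an expected range from 40 nM to 600 nM.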

Compound 4, half-maximal inhibitory concentration: 75 nM
For compound 4 the middle estimate is 2.0-fold (0.30 log units) above the measured one; the measured number falls inside the stated range.
By their numbers in this assay, from the lowest: compounds 4 and 3 (each within the scatter of the next); then compounds 2 and 1 (each within the scatter of the next).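

In this assay, placing a phenyl on the saturated chain carbon bound to a carbonyl carbon and a nitrogen on an aromatic ring gives a 1.3-fold lower number from compound 3 to compound 4 (0.12 log units; within the scatter) and so the two compounds cannot be told apart on this read-out. Among the compounds shown here, this is the first measured change at this position, and it shows that the carbon can carry a group of 6 heavy atoms, a whole six-membered aromatic ring, without any loss of inhibition beyond the usual scatter of the assay. No measurement at hand offers a reason for this result.

The compounds shown leave open whether this tolerance holds for other groups on the same carbon, such as a small methyl, a longer benzyl or a phenyl ring that itself carries a substituent such as methoxy. They also leave open how much the neighbouring methoxycarbonyl group matters, a question that a carboxylic acid or a simple amide in its place could help to answer.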